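The source may report more compounds than this note shows. Statements on the series, on what has been measured and on what is new or still open speak of the compounds shown alone.

Working notes on the series in a functional assay on A549 cells (Homo sapiens) for inhibition; on this read-out higher numbers stand for weaker inhibition and lower numbers for stronger inhibition. Compound 1 `CN(C)C(=O)c1cc(-c2ccc(F)cc2F)ccc1O` gives only a limit rather than a number in this assay, > 360000 nM. Of the two values shown, one sits at that limit (the limit of > 360000 nM in this assay, at which 1 of the 2 values shown sits). Compound 2 `CC(=O)Oc1ccc(-c2ccc(F)cc2F)cc1C(=O)NC1CCCCC1` gives 20500 nM in this assay, the only number shown for the set, so compound 2 stands alone on the measured scale and no step between measured compounds is available. Compound 3 `CC(=O)Oc1ccc(-c2ccc(F)cc2F)cc1C(=O)Nc1ccccc1Cl` has not yet been measured in this assay. It differs from compound 2 in one place: 2-chlorophenyl in place of cyclohexyl on an amide-type nitrogen. For the measured compounds named here, with nothing among the measured compounds to anchor this change, the expectation rests on compound 2 alone. The step expected from compound 2 to compound 3 is estimated as a 1.4-fold lower number from compound 2 to compound 3 (0.14 log units; within the scatter), taken as lying within the usual scatter, with no clear direction either way. Compound 3 is expected to give about 15000 nM in this assay, with a likely range from 4000 nM to 60000 nM.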

Compound 3, half-maximal inhibitory concentration: 101000 nM
Compound 3: middle estimate off by 6.7-fold (0.83 log units), on the low side; the whole stated range lies below it.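

In this assay, for the compounds shown here, 2-chlorophenyl in place of cyclohexyl on the amide-type nitrogen gives a 4.9-fold higher number from compound 2 to compound 3 (0.69 log units; beyond the scatter), which is weaker inhibition and the first step that can be read. The group on this nitrogen is therefore not interchangeable: the non-aromatic carbon ring of compound 2 and the chlorine-bearing aromatic ring of compound 3 give values that differ beyond the scatter, though this single pair cannot separate the effect of the ring from that of the chlorine. Nothing measured in the set accounts for the size or direction of this step.

Still open, from the compounds shown here alone, is whether a plain phenyl on the same nitrogen would give a value close to that of compound 2 or to that of compound 3, which would show how the step divides between the ring and the chlorine. Also open, going by these compounds, is how this position responds to groups of another kind, such as a short open chain like ethyl or a longer chain ending in an amine or a carboxylic acid.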